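The source may hold more compounds than are shown below. What is called first, only, known or untested is meant among the compounds shown, and "the series" means these compounds.

Of the compounds shown here, three that share one core have been measured in a functional assay on HT-29 cells (Homo sapiens) for inhibition, read by luminescence and CellTiter-Glo, with a stated time of 24 h; on this read-out higher numbers stand for an effect only at larger amounts of compound and lower numbers for an effect already at smaller amounts. Compound 1 `COCCn1nc(C(=O)N[C@H]2COc3ccccc3N(C)C2=S)nc1Cc1ccccc1` gives 566 nM. Compound 2 `CN1C(=S)[C@@H](NC(=O)c2nc(Cc3ccccc3)n(CCCC(F)(F)F)n2)COc2ccccc21` gives 2380 nM. Compound 3 `CN1C(=S)[C@@H](NC(=O)c2nc(Cc3ccccc3)n(CCCCCC#N)n2)COc2ccccc21` gives 3830 nM, the highest number of the three; the two steps that lead to it are a 1.6-fold higher number from compound 2 to compound 3 (0.21 log units; within the scatter) and a 6.8-fold higher number from compound 1 to compound 3 (0.83 log units; beyond the scatter). In each case the variation lies on the saturated chain carried by an aromatic nitrogen of the core.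

Compound 4 `CN1C(=S)[C@@H](NC(=O)c2nc(Cc3ccccc3)n(CC3CCOCC3)n2)COc2ccccc21` has not yet been measured. It differs from compound 3 by oxan-4-yl in place of 4-cyanobutyl on a saturated chain carbon bound to an aromatic nitrogen. The step that bears most on this change is a 6.8-fold higher number from compound 1 to compound 3 (0.83 log units; beyond the scatter), in which a methoxy-bearing chain gave way to a nitrile-bearing one and the number rose; the step of a 4.2-fold higher number from compound 1 to compound 2 (0.62 log units; beyond the scatter) points the same way. Compound 4 carries once more a group with an oxygen acceptor, as compound 1 does, though here the oxygen sits within a saturated six-membered ring, so the match to compound 1 is not exact. A move back toward the number of compound 1 is therefore expected, estimated as a 3.2-fold lower number from compound 3 to compound 4 (0.50 log units; beyond the scatter). For compound 4 the expected value in this assay is 1200 nM, with a range from 400 nM to 3600 nM.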

Compound 4, half-maximal effective concentration: 6310 nM
For compound 4 the middle estimate is 5.3-fold (0.72 log units) below the measured one, outside the stated range (above it).
By their numbers in this assay, from the lowest: compound 1; then compounds 2, 3 and 4 (each within the scatter of the next, the first and the last beyond it).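

In this assay, putting the ring-bearing oxan-4-yl in place of the open 4-cyanobutyl on a saturated chain carbon bound to an aromatic nitrogen gives a 1.6-fold higher number from compound 3 to compound 4 (0.22 log units; within the scatter), so this assay does not separate a nitrile on an open chain from an oxygen in a six-membered non-aromatic ring at this place. An oxygen in the group is also not enough to reach the number of compound 1: there is an 11-fold higher number from compound 1 to compound 4 (1.05 log units; beyond the scatter), the widest gap in the set, and a 2.7-fold higher number from compound 2 to compound 4 (0.42 log units; beyond the scatter) shows that the trifluorinated chain of compound 2 also stays apart from the oxan-4-yl group. Nothing measured here explains these differences.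

On these data alone, it remains open whether the low number of compound 1 depends on the oxygen of its methoxymethyl or on the short open chain that carries it; a plain ethyl, a hydroxymethyl or an aminomethyl group in its place would help to decide. The four compounds also leave open whether the same order would hold on a core changed elsewhere.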